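A Hydroxyquinolinyl Group Replaces Nitrophenyl on the Shared Core

The compounds below may be only part of what the source reports. "The series", "measured", "known", "first", "only" and "open" are said of these compounds alone.

Compound 1 `Cc1nc2c3ccccc3ccc2c2nc3c(ccc4ccccc43)c(-c3cccc([N+](=O)[O-])c3)c12` gives 50700 nM in a functional assay on HeLa cells (Homo sapiens) for cytotoxicity, read by MTT assay, with a stated time of 48 h (on this read-out lower numbers stand for stronger inhibition and higher numbers for weaker inhibition), the highest of the two numbers given outright. Compound 3 `Cc1nc2c3ccccc3ccc2c2nc3c(ccc4ccccc43)c(-c3ccc(O)cc3)c12` gives 4630 nM, and the step of an 11-fold lower number from compound 1 to compound 3 (1.04 log units; beyond the scatter) is large. Compound 2 `Cc1nc2c3ccccc3ccc2c2nc3c(ccc4ccccc43)c(-c3ccccc3Cl)c12` reaches only a limit of this assay, > 80000 nM, as noted in the limit of > 80000 nM in this assay, at which 1 of the 3 values shown sits. The step of an at least 1.5-fold higher number from compound 1 to compound 2 (0.19 log units; that floor lies within the scatter) therefore rests on that limit. Compound 4 `Cc1nc2c3ccccc3ccc2c2nc3c(ccc4ccccc43)c(-c3cc(O)nc4ccccc34)c12` differs from compound 1 in one place: 2-hydroxyquinolin-4-yl in place of 3-nitrophenyl on an aromatic carbon. The incoming group carries a hydroxyl, as the 4-hydroxyphenyl of compound 3 did, so the step of an 11-fold lower number from compound 1 to compound 3 (1.04 log units; beyond the scatter) bears most on it, with the 2-chlorophenyl of compound 2 giving no help. A downward step is expected, though smaller given the larger group. Compound 4 is expected at 15000 nM, between 3000 nM and 60000 nM. The expected step is a 3.4-fold lower number from compound 1 to compound 4 (0.53 log units; beyond the scatter).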

Compound 4, half-maximal inhibitory concentration: 4880 nM
Estimate against measurement, compound 4: 3.1-fold (0.49 log units) above; the range from low to high includes it.
By their numbers in this assay, from the lowest: compounds 3 and 4 (each within the scatter of the next); then compound 1. At a limit, above all of these: compound 2.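

At this position in this assay, a second hydroxyl-bearing group gives a drop of the same kind as the first, a 10-fold lower number from compound 1 to compound 4 (1.02 log units; beyond the scatter), so a hydroxyl now goes with the lower numbers on two different aryl groups. Exchanging one such group for the other, with its extra ring, shows little, a 1.1-fold higher number from compound 3 to compound 4 (0.02 log units; within the scatter). The step of an at least 16-fold lower number from compound 2 to compound 4 (1.21 log units; beyond the scatter) rests on a value that is only a limit: the limit of > 80000 nM in this assay, at which 1 of the 4 values shown sits.

The compounds shown leave open whether the hydroxyl itself matters, or whether an amine or a methoxy group in its place would serve as well.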